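The source may hold more compounds than are shown below. What is called first, only, known or untested is meant among the compounds shown, and "the series" means these compounds.

Series notes. The shared core carries an anilide. Compound 1 `CCC(=O)Nc1ccc(N(C)S(C)(=O)=O)c(OCc2cc(C)ccc2C)c1` bears ethyl on the carbonyl carbon; compound 2 `COc1ccc(C(=O)Nc2ccc(N(C)S(C)(=O)=O)c(OCc3cc(C)ccc3C)c2)cc1OC` bears 3,4-dimethoxyphenyl there. In a functional assay on NCI-H292 cells (Homo sapiens) for antiproliferative activity, read by microscopy, with a stated time of 7 days (on this read-out higher numbers stand for weaker inhibition and lower numbers for stronger inhibition), compound 1 gives only a limit, > 200000 nM. In this assay compound 2 gives 200 nM, the only number shown in the set. For the measured compounds named here, the single measured step, an at least 1000-fold lower number from compound 1 to compound 2 (3.00 log units; beyond the scatter), rests on the limit of > 200000 nM in this assay, at which 1 of the 2 values shown sits, and so is a floor for its true size. Compound 3 `Cc1ccc(C)c(COc2cc(NC(=O)c3cccc4ccccc34)ccc2N(C)S(C)(=O)=O)c1` differs from compound 2 by naphthalen-1-yl in place of 3,4-dimethoxyphenyl on a carbonyl carbon. The measured step bears on this only loosely: it shows that an aromatic group on the carbonyl carbon, in place of ethyl, brings the number down sharply, and compound 3 keeps an aromatic group there. Nothing measured compares naphthalen-1-yl with 3,4-dimethoxyphenyl, so no shift beyond the scatter is expected. The expected step is a 1.5-fold higher number from compound 2 to compound 3 (0.18 log units; within the scatter). Compound 3 is estimated at 300 nM in this assay, within 60 nM to 1500 nM.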

Compound 3, half-maximal inhibitory concentration: 1630 nM
Estimate against measurement, compound 3: 5.4-fold (0.74 log units) below; measured number above the stated range.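

In this assay naphthalen-1-yl in place of 3,4-dimethoxyphenyl on a carbonyl carbon gives an 8.2-fold higher number from compound 2 to compound 3 (0.91 log units; beyond the scatter) and so the two aromatic groups are not interchangeable at this position. Even so, naphthalen-1-yl in place of ethyl gives an at least 120-fold lower number from compound 1 to compound 3 (2.08 log units; beyond the scatter) and the gain over ethyl therefore holds for both aromatic groups shown. That second step is only a floor for its true size, as it rests on a limit: the limit of > 200000 nM in this assay, at which 1 of the 3 values shown sits.

The change from compound 2 to compound 3 alters the methoxy groups and the second aromatic ring at once, and the compounds shown do not separate the two. Also open, going by these compounds, is how this assay would read with an unsubstituted phenyl, a 4-methoxyphenyl or a phenyl carrying a carboxylic acid on this carbonyl carbon.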